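The source may hold more compounds than are shown below. What is called first, only, known or untested is meant among the compounds shown, and "the series" means these compounds.

Measured compounds:
Compound 1, `CN1[C@@H]2c3[nH]c4ccccc4c3C[C@H]1[C@H](C#N)N1[C@@H](CNC(=O)c3cccc(C(F)(F)F)c3)c3[nH]c4ccccc4c3C[C@@H]21`; in a functional assay on HCT-116 cells (Homo sapiens) for cytotoxicity, read by MTT assay, with a stated time of 72 h (a lower number here means a stronger inhibitor, a higher number a weaker inhibitor), compound 1 gives 630 nM.
Compound 2, `CN1[C@@H]2c3[nH]c4ccccc4c3C[C@H]1[C@H](C#N)N1[C@@H](CNC(=O)c3ccc(Cl)cc3)c3[nH]c4ccccc4c3C[C@@H]21`; in this assay compound 2 gives 630 nM.
Compound 3, `COc1ccc(C(=O)NC[C@H]2c3[nH]c4ccccc4c3C[C@H]3[C@H]4c5[nH]c6ccccc6c5C[C@@H]([C@H](C#N)N23)N4C)cc1`; in this assay compound 3 gives 430 nM.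

Compound 2 stands level with compound 1 at the digits shown, the two together being the highest of the three numbers; towards compound 3 the step is a 1.5-fold lower number from compound 2 to compound 3 (0.17 log units; within the scatter), which stays within the scatter. Compound 4, `CN1[C@@H]2c3[nH]c4ccccc4c3C[C@H]1[C@H](C#N)N1[C@@H](CNC(=O)c3ccc4ccccc4c3)c3[nH]c4ccccc4c3C[C@@H]21`, is not yet measured. It differs from compound 2 as follows: naphthalen-2-yl in place of 4-chlorophenyl on a carbonyl carbon. Among the compounds with values here, the steps that bear on this exchange are those in which the aryl group on the carbonyl carbon was changed: no change at the digits printed from compound 1 to compound 2 (within the scatter), a 1.5-fold lower number from compound 1 to compound 3 (0.17 log units; within the scatter) and a 1.5-fold lower number from compound 2 to compound 3 (0.17 log units; within the scatter). None of them leaves the scatter, so across three aryl groups on the carbonyl carbon the read-out has been flat. Within the data shown here, no measured step introduces naphthalen-2-yl, so none covers the present change directly. The expectation is therefore a number close to that of compound 2, with no direction preferred. Compound 4 is expected to give 550 nM in this assay, within 250 nM to 1200 nM. The estimated step is a 1.1-fold lower number from compound 2 to compound 4 (0.06 log units; within the scatter), not beyond the scatter.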

Compound 4, half-maximal inhibitory concentration: 420 nM
The estimate for compound 4 lay 1.3-fold (0.12 log units) above the measured number; low and high end bracket the measured number.
By their numbers in this assay, from the lowest: compounds 4, 3, 1 and 2 (each within the scatter of the next).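

In this assay, the exchange on this carbonyl carbon extends the flat read-out to a group with 2 six-membered aromatic rings: naphthalen-2-yl gives no step beyond the scatter against 4-chlorophenyl (a 1.5-fold lower number from compound 2 to compound 4 (0.18 log units; within the scatter)). The same holds against the other two aryl groups (a 1.0-fold lower number from compound 3 to compound 4 (0.01 log units; within the scatter); a 1.5-fold lower number from compound 1 to compound 4 (0.18 log units; within the scatter)), so compounds 1 to 4 all lie within the scatter of one another, and none goes against this pattern. Nothing available accounts for this flat read-out.

Still open, as far as these compounds go, is whether the number holds when the aryl group on the carbonyl carbon gives way to a cyclohexyl ring, a longer alkyl chain, or a group carrying an amine or a carboxylic acid. From the compounds shown here alone, all four compounds keep the amide hydrogen and the nitrile, so the contribution of either to the read-out also remains unknown.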